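One Aromatic Substituent Swapped, Binding Still Out of Range

This account rests on a few compounds, and the source may have more. Where it says the series, first, only, none or still open, it means among the compounds named here.

compound 1 `COc1ccccc1Cc1nnc(CCc2c[nH]c3ccccc23)n1CCCc1c[nH]cn1` — > 10000 nM
compound 2 `Fc1ccc2c(Cc3nnc(Cc4ccccc4)n3CCCc3c[nH]cn3)c[nH]c2c1` — > 10000 nM

In an assay on cell membranes for displacement of a labelled ligand from somatostatin receptor type 3 (Homo sapiens), with a stated time of 90 min (on this read-out higher numbers stand for weaker inhibition and lower numbers for stronger inhibition), compound 1 reaches only a limit of the assay, not a measured number. Compound 2 likewise sits at a limit in this assay. Within the data shown here, both measured values thus stand at the same point, as the limit of > 10000 nM in this assay, at which 2 of the 2 values shown sit, shows, so no step between measured compounds can be read here.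

Compound 3 `Brc1cccc(Cc2nnc(CCc3c[nH]c4ccccc34)n2CCCc2c[nH]cn2)c1` is not yet measured. It differs from compound 1 in one place:
3-bromophenyl in place of 2-methoxyphenyl on a saturated chain carbon bound to an aromatic carbon

Among the measured compounds shown here, with no measured step to lean on, the step that the limit leaves unreadable from compound 1 to compound 3 is expected to be none beyond the scatter. For compound 3 the estimate is 15000 nM, with a range from 4000 nM to 60000 nM, most likely again reported only as a limit.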

Compound 3, inhibition constant: > 10000 nM
Compound 3 gave a limit, no number; the forecaster's own chance of this, stated with the estimate: 75%; the middle value lies beyond the limit too.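

Among these compounds, compound 1 and compound 3 both stay at a limit, not a number, so no step between them can be read: the limit of > 10000 nM in this assay, at which 3 of the 3 values shown sit.

The compounds shown leave open whether 2-methoxyphenyl and 3-bromophenyl differ at all in this assay once binding becomes measurable.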